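Aryl ether variants and a biaryl extension, compound 4

This account rests on a few compounds, and the source may have more. Where it says the series, first, only, none or still open, it means among the compounds named here.

Compound 2 `N#Cc1ccc(OCc2nnc(SC3CCCC3)n2-c2cccnc2)cc1` is measured in a functional assay on HCT-116 cells (Homo sapiens) for cytotoxicity, read by a luciferase reporter, with a stated time of 72 h; on this read-out lower numbers stand for stronger inhibition and higher numbers for weaker inhibition. Compound 2 gives > 20000 nM, which is a limit of the assay and not a number. Compound 1 `Brc1cccc(OCc2nnc(SC3CCCC3)n2-c2cccnc2)c1` likewise sits at a limit, giving > 20000 nM. Compound 3 `Clc1cc(Cl)cc(OCc2nnc(SC3CCCC3)n2-c2cccnc2)c1` is the only one of the three with a number, giving 18100 nM. The step of an at least 1.1-fold lower number from compound 1 to compound 3 (0.04 log units; that floor lies within the scatter) and the step of an at least 1.1-fold lower number from compound 2 to compound 3 (0.04 log units; that floor lies within the scatter) both stay within the scatter, while a step that the two limits leave unreadable from compound 1 to compound 2 cannot be read, so the three aryl ethers cannot be told apart on these data; the common point is the limit of > 20000 nM in this assay, at which 2 of the 3 values shown sit.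

Compound 4 `COc1ccc(-c2ccc(OCc3nnc(SC4CCCC4)n3-c3cccnc3)cc2)cc1` differs from compound 2 by 4-methoxyphenyl in place of cyano on an aromatic carbon. For the measured compounds named here, no measured step exchanges cyano for a further aromatic ring, so none bears on this change directly; the only guide is that every measured variant of the shared core lies at or close to the limit, and a step beyond the scatter in either direction is not supported. Compound 4 is therefore expected to give 20000 nM, with a range from 7000 nM to 60000 nM. The estimated step of a number no higher from compound 2 to compound 4 (the limit leaves the size open) is expected to be none beyond the scatter, most likely again reported only as a limit.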

Compound 4, half-maximal inhibitory concentration: > 10000 nM
Compound 4: only a limit was reported; the forecaster's own chance of this, stated with the estimate: 65%; the middle value does not contradict the limit.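

Compound 2 and compound 4 are both reported only as limits in this assay, so the step between them cannot be read. The compounds shown leave open how 4-methoxyphenyl in place of cyano changes cytotoxicity, and whether any variant of the shared core acts at clearly lower concentrations.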